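This account rests on a few compounds, and the source may have more. Where it says the series, first, only, none or still open, it means among the compounds named here.

Measured in an ADME assay on L1210/0 cells (Mus musculus) for cytotoxicity, with a stated time of 48 h; a higher number here means a weaker inhibitor, a lower number a stronger inhibitor:

- compound 1 `O=c1[nH]c(=O)n([C@H]2C[C@H](O)[C@@H](CO)O2)cc1/C=C/I`: 63900 nM
- compound 2 `C=Cc1cn([C@H]2C[C@H](O)[C@@H](CO)O2)c(=O)[nH]c1=O`: 14200 nM
- compound 3 `O=c1[nH]c(=O)n([C@H]2C[C@H](O)[C@@H](CO)O2)cc1C#CCCO`: > 200000 nM, a limit and not an exact number

Compound 3 has no exact value to work from, and it stands at the limit of > 200000 nM in this assay, at which 1 of the 3 values shown sits. Compound 4 `O=c1[nH]c(=O)n([C@H]2C[C@H](O)[C@@H](CO)O2)cc1C#CCCCO` has not yet been measured. It differs from compound 3 by hydroxymethyl in place of hydroxy on a saturated chain carbon, two bonds along the chain from a triple-bonded carbon. Put simply, hydroxymethyl takes the place of hydroxy on a saturated chain carbon, two bonds along the chain from a triple-bonded carbon, so 4-hydroxybut-1-yn-1-yl becomes 5-hydroxypent-1-yn-1-yl.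

Among the measured compounds shown here, no measured step makes this same change. The nearest evidence comes from the two steps that install the 4-hydroxybut-1-yn-1-yl group, an at least 3.1-fold higher number from compound 1 to compound 3 (0.49 log units; beyond the scatter) and an at least 14-fold higher number from compound 2 to compound 3 (1.14 log units; beyond the scatter). Both point to a high number for compound 3 compared with the compounds that carry the other two groups. Compound 4 keeps the triple bond and the chain-end hydroxy, so it is expected to stay close to compound 3, with no clear step beyond the scatter. The estimated change is an at least 1.1-fold lower number from compound 3 to compound 4 (0.04 log units; that floor lies within the scatter). Compound 4 is expected to give 180000 nM, within an estimated range of 60000 nM to 300000 nM.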

Compound 4, half-maximal inhibitory concentration: > 200000 nM
Compound 4 was reported as a limit (the forecaster's own chance of this, stated with the estimate: 60%); middle value at least 1.1-fold (0.04 log units) from the limit.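

The longer chain does not bring the number back down into the measurable range. Swapping the vinyl group for 5-hydroxypent-1-yn-1-yl gives an at least 14-fold higher number from compound 2 to compound 4 (1.14 log units; beyond the scatter), and swapping 2-iodoethenyl for the same group gives an at least 3.1-fold higher number from compound 1 to compound 4 (0.49 log units; beyond the scatter), so the high number seen with 4-hydroxybut-1-yn-1-yl is not tied to that one chain length. Compound 4 stands at a limit just as compound 3 does, so the two cannot be put in order and the step between them cannot be read: the limit of > 200000 nM in this assay, at which 2 of the 4 values shown sit.

Any real difference between compound 3 and compound 4 stays hidden, and so does the answer to whether adding to the chain matters at all at this position. From the compounds shown here alone, it also remains open whether the high numbers go with the triple bond or with the hydroxy at the chain end, a question that an amine or a carboxylic acid at the chain end, a longer chain, or a chain with no hydroxy could help to settle.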